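The compounds below may be only part of what the source reports. "The series", "measured", "known", "first", "only" and "open" are said of these compounds alone.

In a functional assay, read by spectrophotometry, tested at 100 uM (on this read-out lower numbers stand for stronger inhibition and higher numbers for weaker inhibition), compound 1 (`O=C(/C=C/c1ccccc1)c1cccc(NC(=O)c2cc(-c3ccncc3)n[nH]2)c1`) gives 67100 nM, compound 2 (`O=C(/C=C/c1cccc2ccccc12)c1cccc(NC(=O)c2cc(-c3ccncc3)n[nH]2)c1`) gives 64500 nM and compound 3 (`O=C(/C=C/c1ccc(Cl)cc1)c1cccc(NC(=O)c2cc(-c3ccncc3)n[nH]2)c1`) gives 63900 nM. Compound 3 therefore stands level with the other two, all three numbers lying within the scatter of one another.

Compound 4 (`COc1ccc(/C=C/C(=O)c2cccc(NC(=O)c3cc(-c4ccncc4)n[nH]3)c2)cc1`) carries methoxy in place of chloro on an aromatic carbon, para to a large group: methoxy in place of chloro on an aromatic carbon.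

Within the data shown here, three measured steps bear on this change, since each alters the aromatic group at the end of the chain. These are a 1.1-fold lower number from compound 1 to compound 3 (0.02 log units; within the scatter), for chloro in place of hydrogen, and a 1.0-fold lower number from compound 1 to compound 2 (0.02 log units; within the scatter) and a 1.0-fold lower number from compound 2 to compound 3 (0.00 log units; within the scatter), for the exchanges involving naphthalen-1-yl. All three are small and within the scatter. Among the measured compounds shown here, no methoxy compound has been measured yet, so this precedent is indirect, and three compounds offer only a narrow basis.

No step beyond the scatter is expected in this assay. The expected step is a 1.0-fold lower number from compound 3 to compound 4 (0.01 log units; within the scatter). For compound 4 the estimated value is 62000 nM, with an expected range of 32000 nM to 100000 nM.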

Compound 4, half-maximal inhibitory concentration: 38400 nM
Beside the measured number, compound 4's estimate is 1.6-fold (0.21 log units) above it, and the stated range covers the measured number.
By their numbers in this assay, from the lowest: compounds 4, 3, 2 and 1 (each within the scatter of the next).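

In this assay, methoxy on an aromatic carbon para to a large group brings one hydrogen-bond acceptor where chloro brings none, yet a 1.7-fold lower number from compound 3 to compound 4 (0.22 log units; within the scatter) shows that this exchange stays within the scatter. The comparisons with the other end groups read alike, with a 1.7-fold lower number from compound 2 to compound 4 (0.23 log units; within the scatter) and a 1.7-fold lower number from compound 1 to compound 4 (0.24 log units; within the scatter) both also within the scatter. Hydrogen, chloro, methoxy and naphthalen-1-yl are therefore not told apart at this end of the chain by this read-out.

On these data alone, whether an amine, a carboxylic acid or a longer chain at this place would give a step beyond the scatter remains open. Nothing available bears on these readings, so they stand without an explanation.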